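From ester to acid: one change, no direct precedent

This account rests on a few compounds, and the source may have more. Where it says the series, first, only, none or still open, it means among the compounds named here.

Measured compounds:
compound 1, `O=c1c2ccccc2c(-c2cccnc2)nn1C1CCCC1` — 97%
compound 2, `CCOC(=O)CCCn1nc(-c2cccnc2)c2ccccc2c1=O` — 95%

In an assay on isolated protein (Oryctolagus cuniculus) with Thromboxane-A synthase (Homo sapiens) as the target, tested at 1 uM (on this read-out higher numbers stand for more inhibition at the one concentration tested (going by the name of the read-out) and lower numbers for less inhibition), compound 2 gives 95% and stands lowest of the two numbers shown; the step of a number 2 percentage points lower from compound 1 to compound 2 (within the scatter) lies within the scatter. Compound 3, `O=C(O)CCCn1nc(-c2cccnc2)c2ccccc2c1=O`, differs from compound 2 by hydrogen in place of ethyl on an oxygen next to a carbonyl group. No measured step touches this oxygen; the only step shown altered the group on the aromatic nitrogen and left the read-out essentially unchanged, so it bears only loosely on this change. Compound 3 is therefore expected to land near compound 2, with a wider spread allowed; the expected step is a number 10 percentage points lower from compound 2 to compound 3 (within the scatter). Compound 3 is estimated at 85%, between 60% and 98%.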

Compound 3, a percentage reported as inhibition, at one concentration (the size of the read-out at that concentration, not a potency): 73%
The estimate for compound 3 lay 12 percentage points above the measured number, within the range that was stated.
By their numbers in this assay, from the lowest: compound 3; then compounds 2 and 1 (each within the scatter of the next).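

In this assay, among these compounds, the oxygen next to a carbonyl group proves to be a place where a single change registers: hydrogen in place of ethyl gives a number 22 percentage points lower from compound 2 to compound 3 (beyond the scatter) and so moves the read-out beyond the scatter, which the only earlier step did not do. Set against cyclopentyl on the aromatic nitrogen, 3-carboxypropyl gives a number 24 percentage points lower from compound 1 to compound 3 (beyond the scatter) so the carboxy end of this chain does not match the read-out of compound 1, as the ethoxycarbonyl end of compound 2 does within the scatter. Nothing given here accounts for this loss. Still open, on these data alone, is how a primary amide or an amine at the end of the chain would read in this assay and whether a longer chain carrying the carboxylic acid would read the same as compound 3.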